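Trimming one trifluoromethyl from the urea tail

The source may report more compounds than this note shows. Statements on the series, on what has been measured and on what is new or still open speak of the compounds shown alone.

Measured so far in a functional assay on NCI-H322M cells (Homo sapiens) for inhibition, read by sulforhodamine B assay, with a stated time of 48 h; a higher number here means a weaker inhibitor of growth, a lower number a stronger inhibitor of growth:
compound 1 `O=C(Nc1cccc(-n2cc(-c3ccncc3)c(-c3ccc(Cl)c(O)c3)n2)c1)Nc1cc(C(F)(F)F)cc(C(F)(F)F)c1`: 5390 nM
compound 2 `COc1cc(-c2nn(-c3cccc(NC(=O)Nc4ccc(Cl)c(C(F)(F)F)c4)c3)cc2-c2ccncc2)ccc1Cl`: 13900 nM
compound 3 `COc1cc(-c2nn(-c3cccc(NC(=O)c4ccccc4)c3)cc2-c2ccncc2)ccc1Cl`: > 100000 nM, a limit, not a number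

Compound 1 holds the lowest of the two numbers; compound 2 sits higher, beyond the scatter. Compound 3 sits only at the limit of this assay (the limit of > 100000 nM in this assay, at which 1 of the 3 values shown sits). Going by the values given here, the one measured step, an at least 7.1-fold higher number from compound 2 to compound 3 (0.85 log units; beyond the scatter), shows that the whole arylamino urea tail matters. Compound 4 `O=C(Nc1cccc(-n2cc(-c3ccncc3)c(-c3ccc(Cl)c(O)c3)n2)c1)Nc1cccc(C(F)(F)F)c1` differs from compound 1 by hydrogen in place of trifluoromethyl on an aromatic carbon. Among the compounds with values here, no measured step removes a single trifluoromethyl, so a smaller loss than that step is expected, in the weaker direction. Compound 4 is therefore estimated at 12000 nM, within 5000 nM to 30000 nM. This amounts to an expected step of a 2.2-fold higher number from compound 1 to compound 4 (0.35 log units; beyond the scatter).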

Compound 4, concentration for total growth inhibition: > 32500 nM
Compound 4 ended at the assay's limit; the forecaster's own chance of this, stated with the estimate: 5%; middle value at least 2.7-fold (0.43 log units) away from the limit.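

In this assay, one trifluoromethyl on the urea tail counts on its own and not only the arylamino tail as a whole: the change gives an at least 6.0-fold higher number from compound 1 to compound 4 (0.78 log units; beyond the scatter). Hydrogen at this aromatic carbon is therefore not tolerated as an equal replacement, with the other trifluoromethyl still in place. Compound 4 gives a limit and not a number, so the full size of this step stays unknown: the limit of > 32500 nM in this assay, at which 1 of the 4 values shown sits.

Open, on these data alone, is whether a methyl, a nitrile or an amine on this carbon would hold the value of compound 1, 5390 nM.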